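Triazole thioether series: aryl ketone swap on dimethylamino core

This account rests on a few compounds, and the source may have more. Where it says the series, first, only, none or still open, it means among the compounds named here.

Compound 1 `COc1ccc(-n2c(SCC(=O)c3ccc(F)cc3)nnc2-c2cc(OC)c(OC)c(OC)c2)cc1` carries a 4-fluorophenyl on the carbonyl carbon. In a functional assay on HCT-116 cells (Homo sapiens) for inhibition, read by MTT assay, with a stated time of 48 h (on this read-out lower numbers stand for stronger inhibition and higher numbers for weaker inhibition), compound 1 gives only a limit, > 60000 nM. Compound 2 `COc1ccc(-n2c(SCC(=O)c3ccc(OC)c(O)c3)nnc2-c2cc(OC)c(OC)c(OC)c2)cc1` differs by 3-hydroxy-4-methoxyphenyl in place of 4-fluorophenyl on a carbonyl carbon. In this assay compound 2 likewise returns only a limit, > 60000 nM. The step that the two limits leave unreadable from compound 1 to compound 2 cannot be read because the limit of > 60000 nM in this assay, at which 2 of the 3 values shown sit, holds both values.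

Compound 3 `COc1cc(-c2nnc(SCC(=O)c3ccc(F)cc3)n2-c2ccc(N(C)C)cc2)cc(OC)c1OC` differs from compound 1 by dimethylamino in place of methoxy on an aromatic carbon. In this assay compound 3 gives 31100 nM; the step of an at least 1.9-fold lower number from compound 1 to compound 3 (0.28 log units; that floor lies within the scatter) is all that separates the two cores.

Compound 4 `COc1ccc(C(=O)CSc2nnc(-c3cc(OC)c(OC)c(OC)c3)n2-c2ccc(N(C)C)cc2)cc1O` is not yet measured. It differs from compound 3 by 3-hydroxy-4-methoxyphenyl in place of 4-fluorophenyl on a carbonyl carbon, the same change as from compound 1 to compound 2, at the same place. Since that earlier step stayed unreadable, compound 4 is expected near compound 3, with the step estimated at a 1.3-fold higher number from compound 3 to compound 4 (0.11 log units; within the scatter). The estimate for compound 4 is 40000 nM, between 15000 nM and 60000 nM.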

Compound 4, half-maximal inhibitory concentration: > 100000 nM
Compound 4: only a limit was reported (the forecaster's own chance of this, stated with the estimate: 45%); middle value at least 2.5-fold (0.39 log units) away from the limit.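

On the core of compound 3, 3-hydroxy-4-methoxyphenyl in place of 4-fluorophenyl on a carbonyl carbon gives an at least 3.2-fold higher number from compound 3 to compound 4 (0.50 log units; beyond the scatter) in this assay. The same change on the core of compound 1 cannot be read, and neither can the core change from compound 2 to compound 4, as both values in each pair are limits. The loss is therefore shown on one core only, and the series neither confirms nor refutes that it carries over to the other core.

From the compounds shown here alone, the hydroxy and methoxy groups enter together, so their separate contributions remain open. Also open, going by these compounds, is how a carboxylic acid or a primary amine on that phenyl ring would read out.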